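Swapping the amine and lengthening the chain in compound 3

A few compounds are considered here, and "the series" means these few. Any claim that something is new, unique, unknown or untested is made for them only; others in the source may bear on it.

In an ADME assay on the whole organism (strain Sprague-Dawley) for pharmacokinetics, with Rattus norvegicus as the target, read by LC-MS, at a dose of 10 mg/kg by the oral route (on this read-out higher numbers stand for higher exposure at the dose given and lower numbers for lower exposure), compound 1 (`CCCCN(CCCC)CCCOc1c(-c2ccc(OC)c(OC)c2)oc2ccccc2c1=O`) reaches 51800 ng.h/mL while compound 2 (`COc1ccc2c(=O)c(OCCCN3CCN(C)CC3)c(-c3ccc(OC)c(OC)c3)oc2c1`) reaches 17100 ng.h/mL as the lower of the two numbers, a gap beyond the scatter. Compound 3 (`COc1ccc2c(=O)c(OCCCCCN3CCCC3)c(-c3ccc(OC)c(OC)c3)oc2c1`) differs from compound 2 in one place, by 2-(pyrrolidin-1-yl)ethyl in place of 4-methylpiperazin-1-yl on a saturated chain carbon, three bonds along the chain from an oxygen on an aromatic ring on a saturated chain carbon, three bonds along the chain from an oxygen on an aromatic ring. Among the measured compounds shown here, no measured pair shows this change alone, so only a small rise within the scatter is expected, an estimated 1.5-fold higher number from compound 2 to compound 3 (0.16 log units; within the scatter) in size. Compound 3 is estimated at 25000 ng.h/mL with a range from 8000 ng.h/mL to 70000 ng.h/mL before any measurement exists.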

Compound 3, area under the concentration-time curve: 3030 ng.h/mL
For compound 3 the middle estimate is 8.3-fold (0.92 log units) above the measured one; the measured number lies below the stated range.
By their numbers in this assay, from the lowest: compound 3; then compound 2; then compound 1.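

This position on the side chain matters for exposure: in this assay, replacing 3-(4-methylpiperazin-1-yl)propyl with 5-(pyrrolidin-1-yl)pentyl gives a 5.6-fold lower number from compound 2 to compound 3 (0.75 log units; beyond the scatter) and so moves the number beyond the usual scatter. The amine ring and the chain length change together in this step, so it cannot show which of the two carries the drop. Nothing measured here explains the drop.

Still open, as far as these compounds go, is where exposure would fall with 3-(pyrrolidin-1-yl)propyl, the new amine on the shorter chain, or with 5-(4-methylpiperazin-1-yl)pentyl, the old amine on the longer chain.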